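This account rests on a few compounds, and the source may have more. Where it says the series, first, only, none or still open, it means among the compounds named here.

Measured so far in a functional assay on SiHa cells (Homo sapiens) for antiproliferative activity, read by CCK-8 assay, with a stated time of 72 h; on this read-out lower numbers stand for stronger inhibition and higher numbers for weaker inhibition:
compound 1 `COc1ccc(-c2cncnc2-c2cc(OC)c(OC)c(OC)c2)cc1Cl` gives 1330 nM
compound 2 `COc1ccc(-c2cncnc2-c2cc(OC)c(OC)c(OC)c2)nc1` gives 1750 nM
compound 3 `COc1cc(-c2ncncc2-c2ccc(C(=O)N(C)C)cc2)cc(OC)c1OC` gives 20200 nM

Compound 3 has the highest number of the three, and its distance from both compound 1 and compound 2 lies beyond the scatter. Compound 4 `COc1cc(-c2ncncc2-c2ccc(Br)cc2)cc(OC)c1OC` differs from compound 3 in one place: bromo in place of dimethylcarbamoyl on an aromatic carbon with bromo in place of dimethylcarbamoyl on an aromatic carbon. Within the data shown here, no measured step covers this exchange directly. Among the measured compounds shown here, the only measured step, a 1.3-fold higher number from compound 1 to compound 2 (0.12 log units; within the scatter), stays within the scatter, so two different groups on the shared core gave similar numbers. Three compounds are too few to establish a pattern, and compound 3 is the only one carrying dimethylcarbamoyl. With that group gone, compound 4 is expected to fall clearly below compound 3 and to lie nearer the level of compound 1 and compound 2 in this assay with wide uncertainty. The expected change is a 13-fold lower number from compound 3 to compound 4 (1.13 log units; beyond the scatter) and it lies beyond the scatter. For compound 4 the estimate is 1500 nM with an expected range from 300 nM to 8000 nM as the likely span.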

Compound 4, half-maximal inhibitory concentration: 2960 nM
For compound 4 the middle estimate is 2.0-fold (0.30 log units) below the measured one; low and high end bracket the measured number.
By their numbers in this assay, from the lowest: compounds 1, 2 and 4 (each within the scatter of the next, the first and the last beyond it); then compound 3.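

In this assay, bromo in place of dimethylcarbamoyl, para to a large group, gives a clear but modest gain (a 6.8-fold lower number from compound 3 to compound 4 (0.83 log units; beyond the scatter)), so the high number of compound 3 goes with dimethylcarbamoyl and not with the shared core. The 4-bromophenyl group brings this series back to the level of the other aryl groups: the step to compound 2 stays within the scatter (a 1.7-fold higher number from compound 2 to compound 4 (0.23 log units; within the scatter)), while the step to compound 1 only just exceeds it (a 2.2-fold higher number from compound 1 to compound 4 (0.35 log units; beyond the scatter)). Nothing measured here accounts for these differences.

The compounds shown leave open whether the high number belongs to dimethylcarbamoyl as a whole or to only part of it. They also leave open how a primary carboxamide, a carboxylic acid or an amine on the same aromatic carbon would stand.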